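Working notes: from fluoro to nitro at compound 4

The source may report more compounds than this note shows. Statements on the series, on what has been measured and on what is new or still open speak of the compounds shown alone.

- compound 1 `COC(=O)/C(=C/c1ccccc1)CN1C(=O)[C@@H](OC)[C@H]1c1ccc(F)cc1`: 27900 nM
- compound 2 `COC(=O)/C(=C/c1ccccc1)CN1C(=O)[C@@H](OC)[C@H]1c1cccc(Cl)c1`: "not toxic" (no number reported)
- compound 3 `COC(=O)/C(=C/c1ccccc1)CN1C(=O)[C@@H](OC)[C@H]1c1cccc(F)c1`: 38500 nM

All three were run in an ADME assay on cells (Epithelial cell, Homo sapiens) for antiproliferative activity, read by MTT assay, with a stated time of 48 h; on this read-out lower numbers stand for stronger inhibition and higher numbers for weaker inhibition. For the measured compounds named here, only two of them have numbers, and these lie within the scatter of each other, so compound 3 cannot be ranked apart from compound 1: a 1.4-fold higher number from compound 1 to compound 3 (0.14 log units; within the scatter). Compound 2, the 3-chlorophenyl member, gave no number.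

The next member, compound 4 `COC(=O)/C(=C/c1ccccc1)CN1C(=O)[C@@H](OC)[C@H]1c1cccc([N+](=O)[O-])c1`, has nitro in place of fluoro on an aromatic carbon, 3-fluorophenyl to 3-nitrophenyl (nitro in place of fluoro on an aromatic carbon).

Going by the values given here, the only measured step moves the fluoro group and does not replace it, so no measured step covers this exchange. Compound 2 adds no size either. The expectation therefore rests on compound 3 at 38500 nM and on the small step of a 1.4-fold higher number from compound 1 to compound 3 (0.14 log units; within the scatter). No change beyond the scatter is expected in this assay, and a result without a number remains possible.

The expected step is a 1.1-fold lower number from compound 3 to compound 4 (0.04 log units; within the scatter).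

Compound 4 is estimated at 35000 nM, with an expected range from 12000 nM to 100000 nM.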

Compound 4, half-maximal inhibitory concentration: "not toxic" (no number reported)
Nothing numeric was reported for compound 4, and the estimate cannot be compared.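

For the compounds shown here, compound 4, like compound 2, gave no number in this assay, so no step from compound 3 to compound 4 can be read. The compounds shown leave open how 3-nitrophenyl compares with 3-fluorophenyl on this read-out. No measured evidence bears on this result.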